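A Fluoro-to-Hydroxy Swap Measured Against an Assay Ceiling

The source may hold more compounds than are shown below. What is called first, only, known or untested is meant among the compounds shown, and "the series" means these compounds.

Measured compounds, all in a functional assay on MDA-MB-231 cells (Homo sapiens) for cytotoxicity, read by MTT assay, with a stated time of 48 h; a higher number here means a weaker inhibitor, a lower number a stronger inhibitor:
- compound 1 `Fc1cccc(-c2nc(Nc3ccccc3)c3ccccc3n2)c1` gives a limit of the assay, > 50000 nM
- compound 2 `Fc1cccc(-c2nc(Nc3ccccc3F)c3cc(F)ccc3n2)c1` gives a limit of the assay, > 50000 nM
- compound 3 `Oc1cccc(Nc2nc(-c3cccc(F)c3)nc3ccc(F)cc23)c1` gives a limit of the assay, > 50000 nM

Compound 2 therefore stands at a limit and not at a number, and so do the two others, so none of the three can be ranked against another. Within the data shown here, the single step between neighbours that differ in one place, a step that the two limits leave unreadable from compound 2 to compound 3, runs from one limit to another and its size cannot be read.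

Compound 4 `Oc1ccccc1Nc1nc(-c2cccc(F)c2)nc2ccc(F)cc12` differs from compound 2 in one place: hydroxy in place of fluoro on an aromatic carbon; seen one bond further out this is (2-fluorophenyl)amino to (2-hydroxyphenyl)amino. Among the measured compounds shown here, the only evidence bearing on this step is the limit of > 50000 nM in this assay, at which 3 of the 3 values shown sit, which gives no direction and no size. Nothing in the measured compounds points to a reading below the limit, so compound 4 is expected to stay at or near the limit, with a step that the limit leaves unreadable from compound 2 to compound 4 as the expected step. The estimate for compound 4 is 70000 nM, within a range of 20000 nM to 250000 nM.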

Compound 4, half-maximal inhibitory concentration: > 50000 nM
Compound 4: no number, only a limit (the forecaster's own chance of this, stated with the estimate: 85%); the middle value is on the limit's open side.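

In this assay compound 4 gives > 50000 nM, a limit of the assay and not a number. Among these compounds, no step from compound 2 or compound 3 to compound 4 can be read. The compounds shown leave open whether swapping fluoro for hydroxy changes cytotoxicity at all.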